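Sulfonyl Variation Toward a Piperazine Analogue

This account rests on a few compounds, and the source may have more. Where it says the series, first, only, none or still open, it means among the compounds named here.

Compound 1 `CCN(CC)C(=O)c1ccc(NC(=O)C(C)(O)C(F)(F)F)cc1`, compound 2 `CCC(C)N(C(C)CC)S(=O)(=O)c1ccc(NC(=O)C(C)(O)C(F)(F)F)cc1` and compound 3 `CC(C)CN(CC(C)C)S(=O)(=O)c1ccc(NC(=O)C(C)(O)C(F)(F)F)cc1` share one core and differ only in a single side group. In an assay on a protein complex (Cavia porcellus) with sulfonylurea receptors; K-ATP channels (Homo sapiens) as the target (a lower number here means a stronger inhibitor, a higher number a weaker inhibitor), compound 1 reaches only the limit > 30000 nM. Compound 2 likewise stops at the limit > 30000 nM. Compound 3 also sits at the limit > 30000 nM, so its standing is known only as a limit; indeed (the limit of > 30000 nM in this assay, at which 3 of the 3 values shown sit). The step that the two limits leave unreadable from compound 2 to compound 3 is therefore unreadable. Compound 4 `CC(O)(C(=O)Nc1ccc(S(=O)(=O)N2CCNCC2)cc1)C(F)(F)F` differs from compound 3 in that (piperazin-1-yl in place of diisobutylamino on a sulfonyl sulfur). Among the measured compounds shown here, no measured step reads on this change, so no direction can be drawn from the data. Compound 4 is therefore expected to stay near the limit, with an expected step that the limit leaves unreadable from compound 3 to compound 4 and an estimated value of 40000 nM, ranging from 8000 nM to 200000 nM.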

Compound 4, half-maximal inhibitory concentration: > 30000 nM
Compound 4: a limit, no number; the forecaster's own chance of this, stated with the estimate: 85%; the middle value does not contradict the limit.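

No new step can be read from compound 4 to compound 2 or compound 3, because each value is only a limit, not a number: the limit of > 30000 nM in this assay, at which 4 of the 4 values shown sit.

The compounds shown leave open how any of these side groups affects inhibitor strength in this assay.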